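The compounds below may be only part of what the source reports. "The series", "measured", "known", "first", "only" and "open" are said of these compounds alone.

In an ADME assay on NHDF cells (Homo sapiens) for cytotoxicity, read by MTT assay, with a stated time of 72 h (a lower number here means a stronger inhibitor, a higher number a weaker inhibitor), three compounds sharing one core lie within the scatter of one another: compound 1 (`COc1cccc(/C=C2\CCC/C(=C\c3cccc(Br)c3)C2=O)c1OC`) gives 23900 nM, compound 2 (`COc1ccccc1/C=C1\CCC/C(=C\c2cccc(OC)c2OC)C1=O`) gives 31300 nM and compound 3 (`COc1cccc(/C=C2\CCC/C(=C\c3cccc(OC)c3OC)C2=O)c1`) gives 16400 nM. Compound 4 (`COc1cccc(/C=C2\CCC/C(=C\c3ccc(Cl)c(Cl)c3)C2=O)c1OC`) differs from compound 3 at one place: 3,4-dichlorophenyl in place of 3-methoxyphenyl on a double-bonded chain carbon bound to a double-bonded ring carbon. The measured steps at this place are a 1.5-fold lower number from compound 1 to compound 3 (0.16 log units; within the scatter), a 1.3-fold higher number from compound 1 to compound 2 (0.12 log units; within the scatter) and a 1.9-fold lower number from compound 2 to compound 3 (0.28 log units; within the scatter), each within the scatter. Within the data shown here, no step beyond the scatter is therefore expected in this assay, although no dichlorinated compound has been measured. The expected step is a 1.2-fold higher number from compound 3 to compound 4 (0.09 log units; within the scatter). For compound 4, the estimated value is 20000 nM, with an expected range of 10000 nM to 38000 nM.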

Compound 4, half-maximal inhibitory concentration: 25500 nM
Compound 4: the middle estimate sits 1.3-fold (0.11 log units) below what was measured; the range from low to high includes it.
By their numbers in this assay, from the lowest: compounds 3, 1, 4 and 2 (each within the scatter of the next).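

In this assay, 3,4-dichlorophenyl, which has no hydrogen-bond acceptor, sits within the scatter of all three earlier compounds at this place: a 1.6-fold higher number from compound 3 to compound 4 (0.19 log units; within the scatter), a 1.2-fold lower number from compound 2 to compound 4 (0.09 log units; within the scatter) and a 1.1-fold higher number from compound 1 to compound 4 (0.03 log units; within the scatter). The four compounds thus show no step beyond the scatter, even with a chlorine-bearing ring in place of a methoxy-bearing one. Nothing available gives a reason for this. Going by these compounds, whether an amine or a carboxylic acid on this ring would give a step beyond the scatter remains open.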